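This account rests on a few compounds, and the source may have more. Where it says the series, first, only, none or still open, it means among the compounds named here.

Measured so far in a functional assay on NCI-H460 cells (Homo sapiens) for cytotoxicity, read by MTT assay, with a stated time of 48 h; on this read-out lower numbers stand for stronger inhibition and higher numbers for weaker inhibition:
- compound 1 `C=C1C(=O)O[C@H]2CC3=C[C@H](C/C(C)=C/[C@@H](OC(=O)c4ccc([N+](=O)[O-])cc4)[C@H]12)OC3=O`: > 10000 nM (a limit)
- compound 2 `C=C1C(=O)O[C@H]2CC3=C[C@H](C/C(C)=C/[C@@H](OC(=O)/C=C/c4ccc(N(C)C)cc4)[C@H]12)OC3=O`: 1300 nM
- compound 3 `C=C1C(=O)O[C@H]2CC3=C[C@H](C/C(C)=C/[C@@H](OC(=O)C4CCC(F)(F)CC4)[C@H]12)OC3=O`: > 10000 nM (a limit)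

Compound 3 stands at the limit of > 10000 nM in this assay, at which 2 of the 3 values shown sit. Its entry is a limit and not a number.

Next is compound 4 `C=C1C(=O)O[C@H]2CC3=C[C@H](C/C(C)=C/[C@@H](OC(=O)/C=C/c4cccs4)[C@H]12)OC3=O`, where 2-(thiophen-2-yl)ethenyl takes the place of 4,4-difluorocyclohexyl on a carbonyl carbon: 2-(thiophen-2-yl)ethenyl in place of 4,4-difluorocyclohexyl on a carbonyl carbon.

The nearest measured change is an at least 7.6-fold higher number from compound 2 to compound 3 (0.88 log units; beyond the scatter), in which 4,4-difluorocyclohexyl replaces 2-(4-(dimethylamino)phenyl)ethenyl. The other readable change is an at least 7.6-fold lower number from compound 1 to compound 2 (0.88 log units; beyond the scatter). Both sizes are bounded by a limit, so they are minimum sizes only. The remaining change, a step that the two limits leave unreadable from compound 1 to compound 3, gives no size.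

Among these compounds, only compound 2 has an ethenyl group, and only compound 2 gives a number, 1300 nM. Within the data shown here, no measured step covers the exchange of its substituted phenyl for thiophen-2-yl, so the expectation is loose.

In this assay the expected change is an at least 3.3-fold lower number from compound 3 to compound 4 (0.52 log units; beyond the scatter), towards a lower number. For compound 4 the estimated value is 3000 nM, with an expected range of 800 nM to 10000 nM.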

Compound 4, half-maximal inhibitory concentration: 2900 nM
Estimate against measurement, compound 4: 1.0-fold (0.01 log units) above; the measured number falls inside the stated range.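

In this assay, compound 2 is no longer the only ester at this carbonyl carbon to give a number: with 2-(thiophen-2-yl)ethenyl there is an at least 3.4-fold lower number from compound 3 to compound 4 (0.53 log units; beyond the scatter) and an at least 3.4-fold lower number from compound 1 to compound 4 (0.53 log units; beyond the scatter). Among the compounds shown, both ethenyl esters give numbers while the 4-nitrophenyl and 4,4-difluorocyclohexyl esters do not, yet the ring on the ethenyl still counts: thiophen-2-yl in place of 4-(dimethylamino)phenyl brings a 2.2-fold higher number from compound 2 to compound 4 (0.35 log units; beyond the scatter). Compound 1 and compound 3 remain limits of the assay, so the two steps from them are minimum sizes only: the limit of > 10000 nM in this assay, at which 2 of the 4 values shown sit.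

From the compounds shown here alone, whether the ethenyl link or the ring at its end matters more stays open. A saturated ethyl link, a plain phenyl on the ethenyl, or 4-(dimethylamino)phenyl set directly on the carbonyl carbon would separate the two.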